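This account rests on a few compounds, and the source may have more. Where it says the series, first, only, none or still open, it means among the compounds named here.

Compounds measured in an assay on HEK293 cells for positive allosteric modulation of metabotropic glutamate receptor 5 (Homo sapiens), read by FLIPR, with a stated time of 1 h; on this read-out higher numbers stand for an effect only at larger amounts of compound and lower numbers for an effect already at smaller amounts:
- Compound 1, `CC(C)CN1CCc2nc(C#Cc3ccccc3)sc2C1`: in this assay compound 1 gives only a limit, > 10000 nM.
- Compound 2, `CC1CCC(C(=O)N2CCc3nc(C#Cc4ccccc4)sc3C2)CC1`: compound 2 gives 190 nM.
- Compound 3, `O=C(CC1CCOCC1)N1CCc2nc(C#Cc3ccccc3)sc2C1`: compound 3 gives 470 nM.

Among the two numbers in hand, compound 3 stands at the higher one; its nearest neighbour is compound 2, and that step, a 2.5-fold higher number from compound 2 to compound 3 (0.39 log units; beyond the scatter), lies beyond the scatter. Among the measured compounds shown here, compound 1 is the one value that is a limit rather than a number, a point recorded as the limit of > 10000 nM in this assay, at which 1 of the 3 values shown sits.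

The next compound, compound 4, `O=C(N1CCCC1)N1CCc2nc(C#Cc3ccccc3)sc2C1`, changes the group on the same carbonyl carbon that was changed between compound 2 and compound 3: pyrrolidin-1-yl in place of (oxan-4-yl)methyl on a carbonyl carbon.

For the measured compounds named here, only one measured step bears on this change, the one from compound 2 to compound 3, and it was modest. Both exchanges replace a ring-bearing group on the carbonyl carbon, so for compound 4 the expected outcome in this assay is a step of similar modest size, most likely toward a somewhat higher number, though a result within the scatter of compound 3 would not be surprising. The estimate for compound 4 is therefore 900 nM, with an expected range from 250 nM to 3500 nM, which as a step means an expected 1.9-fold higher number from compound 3 to compound 4 (0.28 log units; within the scatter).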

Compound 4, half-maximal effective concentration: 9.8 nM
Beside the measured number, compound 4's estimate is 92-fold (1.96 log units) above it; measured number below the stated range.
By their numbers in this assay, from the lowest: compound 4; then compound 2; then compound 3. At a limit, above all of these: compound 1.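

In this assay, among the compounds shown here, the group on the carbonyl carbon can move the number much further than the one earlier step showed: after the modest 2.5-fold higher number from compound 2 to compound 3 (0.39 log units; beyond the scatter), pyrrolidin-1-yl in place of (oxan-4-yl)methyl gives a 48-fold lower number from compound 3 to compound 4 (1.68 log units; beyond the scatter), and pyrrolidin-1-yl in place of 4-methylcyclohexyl gives a 19-fold lower number from compound 2 to compound 4 (1.29 log units; beyond the scatter). So the earlier pair understated how much this position matters, and of the three groups compared on this carbonyl carbon, pyrrolidin-1-yl is the only one that brings a nitrogen, with 5 heavy atoms against 7 for (oxan-4-yl)methyl. On the amine nitrogen in a ring, (pyrrolidin-1-yl)carbonyl in place of isobutyl gives an at least 1000-fold lower number from compound 1 to compound 4 (3.00 log units; beyond the scatter), a step read from compound 1's value, which is a limit and not a number: the limit of > 10000 nM in this assay, at which 1 of the 4 values shown sits.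

The compounds shown do not separate the nitrogen of pyrrolidin-1-yl from its five-membered ring or its heavy-atom count. On these data alone, it remains open how a cyclopentyl group, which keeps the ring size without the nitrogen, or a piperidin-1-yl, a morpholin-4-yl or an open-chain diethylamino group on the same carbonyl carbon would read.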